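Replacing thiophen-3-yl with 1-benzofuran-2-yl on the shared core

This account rests on a few compounds, and the source may have more. Where it says the series, first, only, none or still open, it means among the compounds named here.

In a functional assay on K562 cells (Homo sapiens), read by MTT assay, with a stated time of 72 h (a higher number here means a weaker inhibitor, a lower number a stronger inhibitor), compound 1 `Cc1ncnc2c1c(-c1ccoc1)cn2[C@@H]1O[C@H](CO)[C@@H](O)[C@H]1O` gives > 20000 nM, which is a limit of the assay and not a number. Among the measured compounds shown here, compound 2 `Cc1ncnc2c1c(-c1ccsc1)cn2[C@@H]1O[C@H](CO)[C@@H](O)[C@H]1O` gives 320 nM, the only actual number so far, so it has no numeric value to be ranked against.

The next structure is compound 3 `Cc1ncnc2c1c(-c1cc3ccccc3o1)cn2[C@@H]1O[C@H](CO)[C@@H](O)[C@H]1O`. The change is 1-benzofuran-2-yl in place of thiophen-3-yl on an aromatic carbon. For the measured compounds named here, the group at this carbon is the one varied in the only measured step, an at least 62-fold lower number from compound 1 to compound 2 (1.79 log units; beyond the scatter). That step is large and shows that exchanging one ring here can move the result sharply. It is a single step, however, and it involves no fused ring. Like the furan-3-yl of compound 1, the entering group holds oxygen rather than sulfur, and it is also larger. A sizeable move towards a higher number, meaning a weaker inhibitor, is therefore expected in this assay, though probably a smaller one than the measured step. The expected change is a 9.4-fold higher number from compound 2 to compound 3 (0.97 log units; beyond the scatter). For compound 3 the estimated value is 3000 nM, with an expected range from 400 nM to 20000 nM.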

Compound 3, half-maximal inhibitory concentration: 19500 nM
Compound 3: the middle estimate sits 6.5-fold (0.81 log units) below what was measured; low and high end bracket the measured number.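

In this assay, the fused group at this aromatic carbon reverses the earlier gain, with a 61-fold higher number from compound 2 to compound 3 (1.78 log units; beyond the scatter) as the step, and of the three groups shown only thiophen-3-yl stands clearly apart from the other two. Compound 1 gives > 20000 nM as a limit of the assay and not a number. Read against that limit, the change from furan-3-yl to 1-benzofuran-2-yl is an at least 1.0-fold lower number from compound 1 to compound 3 (0.01 log units; that floor lies within the scatter) and gives no order between the two groups, the comparison being capped at the top of the range: the limit of > 20000 nM in this assay, at which 1 of the 3 values shown sits.

The change from thiophen-3-yl to 1-benzofuran-2-yl exchanges sulfur for oxygen and adds a six-membered aromatic ring at once, and the compounds shown do not separate these two changes; a 1-benzothiophen-2-yl group at this carbon would keep the sulfur and add the fused ring. Also open, going by these compounds, is how this assay responds to a phenyl group, an amine or a short alkyl chain at the same carbon on the shared core.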